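Polyamine chain extension on the farnesyl-type series

This account rests on a few compounds, and the source may have more. Where it says the series, first, only, none or still open, it means among the compounds named here.

Measured in a toxicity assay on CHO cells (Cricetulus griseus) for cytotoxicity, read by WST assay, with a stated time of 24 h; on this read-out higher numbers stand for weaker inhibition and lower numbers for stronger inhibition:
- compound 1 `CC(C)=CCCC(C)=CCNCCCNCCCCNCCCN` gives > 150000 nM, a limit of the assay
- compound 2 `CC(C)=CCC/C(C)=C\CCC(C)=CCNCCCN` gives 32100 nM
- compound 3 `CC(C)=CCC/C(C)=C\CCC(C)=CCNCCCNCCCN` gives 30200 nM

Compound 3 lies within the scatter of compound 2, and the only other entry is the limit of compound 1 (the limit of > 150000 nM in this assay, at which 1 of the 3 values shown sits). Compound 4 `CC(C)=CCC/C(C)=C\CCC(C)=CCNCCCNCCCCNCCCN` differs from compound 3 by ((3-aminopropyl)amino)methyl in place of amino on a saturated chain carbon, three bonds along the chain from an amine nitrogen. Among the measured compounds shown here, the one measured step that bears on this, also a lengthening of the amine chain, is a 1.1-fold lower number from compound 2 to compound 3 (0.03 log units; within the scatter). No step beyond the scatter is therefore expected in this assay. The expected step is a 1.1-fold higher number from compound 3 to compound 4 (0.03 log units; within the scatter). The estimate for compound 4 is 32000 nM, with an expected range of 13000 nM to 80000 nM.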

Compound 4, half-maximal inhibitory concentration: 143000 nM
The estimate for compound 4 lay 4.5-fold (0.65 log units) below the measured number; the measured number lies above the stated range.
By their numbers in this assay, from the lowest: compounds 3 and 2 (each within the scatter of the next); then compound 4. At a limit, above all of these: compound 1.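

In this assay, the first lengthening of the amine chain stayed within the scatter (a 1.1-fold lower number from compound 2 to compound 3 (0.03 log units; within the scatter)), but the next does not: ((3-aminopropyl)amino)methyl in place of amino gives a 4.7-fold higher number from compound 3 to compound 4 (0.68 log units; beyond the scatter). Counted from the shorter chain, 4-((3-aminopropyl)amino)butyl in place of hydrogen on an amine nitrogen gives a 4.5-fold higher number from compound 2 to compound 4 (0.65 log units; beyond the scatter). The step that can be stated from the limit of compound 1 is only a floor: an at least 1.0-fold lower number from compound 1 to compound 4 (0.02 log units; that floor lies within the scatter). Compound 1 stands at a limit: the limit of > 150000 nM in this assay, at which 1 of the 4 values shown sits.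

Open, from the compounds shown here alone, is whether the higher number follows the added amine nitrogens or the added chain length. An all-carbon chain of the same length in place of the polyamine tail would separate the two.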